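The source may hold more compounds than are shown below. What is called first, only, known or untested is meant among the compounds shown, and "the series" means these compounds.

Three measured compounds share one core and differ only in the ring attached to the carbonyl carbon. Compound 1 `COc1cc(-c2cc(/C=C/C(=O)c3ccc(N)cc3)[nH]n2)cc(OC)c1OC` carries a 4-aminophenyl there, compound 2 `COc1ccc(C(=O)/C=C/c2cc(-c3cc(OC)c(OC)c(OC)c3)n[nH]2)cc1OC` a 3,4-dimethoxyphenyl, and compound 3 `COc1cc(-c2cc(/C=C/C(=O)c3ccc(F)c(F)c3)[nH]n2)cc(OC)c1OC` a 3,4-difluorophenyl. In a functional assay on OVCAR-4 cells (Homo sapiens) for inhibition, read by sulforhodamine B assay, with a stated time of 48 h (on this read-out lower numbers stand for stronger inhibition of growth and higher numbers for weaker inhibition of growth), compound 1 gives 5440 nM, compound 2 gives 16600 nM, and compound 3 gives 71800 nM. Compound 2 thus stands second highest of the three numbers: one exchange of the ring gives a 3.1-fold higher number from compound 1 to compound 2 (0.48 log units; beyond the scatter), the next gives a 4.3-fold higher number from compound 2 to compound 3 (0.64 log units; beyond the scatter), and end to end the change is a 13-fold higher number from compound 1 to compound 3 (1.12 log units; beyond the scatter).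

Compound 4 `COc1cc(C(=O)/C=C/c2cc(-c3cc(OC)c(OC)c(OC)c3)n[nH]2)cc(OC)c1OC` is built from compound 2 by a single change: methoxy in place of hydrogen on an aromatic carbon. For the measured compounds named here, none of the measured steps adds one group to a ring that is otherwise kept; each exchanges the whole ring on the carbonyl carbon, so they show only roughly how much this position can move the number. Those exchanges were modest to large, but adding one methoxy to a ring already bearing methoxy groups is a smaller alteration than any of them. The step expected in this assay is therefore a 1.4-fold lower number from compound 2 to compound 4 (0.14 log units; within the scatter), not clearly beyond the scatter in either direction. On that basis compound 4 is estimated at 12000 nM, with a range from 4000 nM to 40000 nM.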

Compound 4, concentration for total growth inhibition: 2760 nM
Beside the measured number, compound 4's estimate is 4.3-fold (0.64 log units) above it; the whole stated range lies above it.
By their numbers in this assay, from the lowest: compounds 4 and 1 (each within the scatter of the next); then compound 2; then compound 3.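

The earlier compounds shown here showed only exchanges of the whole ring on the carbonyl carbon, whereas here that ring is kept and a single methoxy is added on an aromatic carbon, ortho to a methoxy group and meta to a large group. In this assay, this small addition gives a 6.0-fold lower number from compound 2 to compound 4 (0.78 log units; beyond the scatter), a step toward stronger inhibition of growth that is classed as modest, like the whole-ring exchange that gives a 4.3-fold higher number from compound 2 to compound 3 (0.64 log units; beyond the scatter). So this position responds to one added group as well as to a new ring, and compound 4 now lies within the scatter of compound 1 even though their rings differ; nothing shown here gives a measured reason for the gain.

As far as these compounds go, what remains open is whether the gain belongs to methoxy itself, since an ethoxy, a hydroxyl or a chlorine on the same carbon could give a different number. From the compounds shown here alone, it is also open whether an amine on the ring of compound 4 would add to the effect of the methoxy groups or leave the number where it stands.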